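Chloro in Place of Bromo Across Two Hydroxamic Acid Cores

A few compounds are considered here, and "the series" means these few. Any claim that something is new, unique, unknown or untested is made for them only; others in the source may bear on it.

Measured compounds:
compound 1, `O=C(CCC1=CCN(CCCc2ccc(Br)cc2)C1=O)NO`, in a functional assay on PC-3 cells (Homo sapiens) for inhibition, read by sulforhodamine B assay (on this read-out lower numbers stand for stronger inhibition of growth and higher numbers for weaker inhibition of growth), compound 1 gives 3480 nM
compound 2, `O=C(CCC1=CCN(CCCc2ccc(Cl)cc2)C1=O)NO`, in this assay compound 2 gives 3480 nM
compound 3, `O=C(CCC1=CCN(Cc2cccc(Br)c2)C1=O)NO`, in this assay compound 3 gives 4620 nM

The step from compound 1 to compound 2 is the change (chloro in place of bromo on an aromatic carbon); it produced no change at the digits printed from compound 1 to compound 2 (within the scatter). Compound 3 carries a different core from compound 1; the difference between the two cores is not broken down here. Its value sits close to those of compound 1 and compound 2, all within the scatter of one another.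

Compound 4, `O=C(CCC1=CCN(Cc2cccc(Cl)c2)C1=O)NO`, has not yet been measured. It differs from compound 3 by chloro in place of bromo on an aromatic carbon. This is the same kind of change as that from compound 1 to compound 2, but the place differs: in the measured pair the halogen sits para to a large group, whereas in compound 4 it sits meta to a large group.

Among the measured compounds shown here, because the first instance gave no change at the digits printed from compound 1 to compound 2 (within the scatter), the step from compound 3 to compound 4 in this assay is expected to be a 1.0-fold lower number from compound 3 to compound 4 (0.00 log units; within the scatter). On that basis compound 4 is estimated at 4600 nM, with a range from 2300 nM to 9200 nM.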

Compound 4, concentration for 50% growth inhibition: 4620 nM
Beside the measured number, compound 4's estimate is 1.0-fold (0.00 log units) below it; measured number inside the range.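

In this assay, putting chloro in place of bromo on the aromatic carbon, meta to a large group, gave no change at the digits printed from compound 3 to compound 4 (within the scatter). The outcome on this second core therefore matches the one on the core of compound 1, so in this series the change carried from one core to the other without a step beyond the scatter: the same change on two cores in this assay, no change at the digits printed (within the scatter) from compound 1 to compound 2 and no change at the digits printed (within the scatter) from compound 3 to compound 4, 1.0-fold (0.00 log units) apart, within the scatter of two such steps. This shows only that the two halogens were interchangeable in these two pairs in this one assay; two pairs set no rule for other cores or other read-outs, and they do not explain why the values stayed level.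

The compounds shown leave open whether a fluoro or a methoxy group in place of the halogen would leave the growth inhibition equally level on both cores. They also leave open what a carboxylic acid in place of the hydroxamic acid, or a longer chain carrying the aromatic ring, would give.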